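Amino in place of hydrogen on the shared core

The source may report more compounds than this note shows. Statements on the series, on what has been measured and on what is new or still open speak of the compounds shown alone.

In a functional assay on CAKI-1 cells (Homo sapiens) for cytotoxicity, read by sulforhodamine B assay, with a stated time of 48 h (on this read-out lower numbers stand for higher toxicity in this test and higher numbers for lower toxicity in this test), compound 2 `ClCc1ccccc1Cn1cnc2c(Cl)ncnc21` gives 9330 nM. Of the two compounds with numbers this is the highest; its nearest neighbour is compound 1 `ClCc1ccccc1Cn1cnc2c(Cl)nc(Cl)nc21`, which gives 3090 nM. Compound 3 `ClCc1cccc(Cn2cnc3ncnc(Cl)c32)c1` gives only a limit of the assay, > 100000 nM. For the measured compounds named here, the one step between measured compounds that differ in a single place is a 3.0-fold higher number from compound 1 to compound 2 (0.48 log units; beyond the scatter). The third value is described by the limit of > 100000 nM in this assay, at which 1 of the 3 values shown sits.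

Compound 4 `Nc1nc(Cl)c2ncn(Cc3ccccc3CCl)c2n1` has not yet been measured. From compound 2 it differs by amino in place of hydrogen on an aromatic carbon. The step from compound 1 to compound 2 replaced a chloro group with hydrogen on an aromatic carbon and gave a modest rise in the number; the change to compound 4 again puts a substituent on an aromatic carbon, but an amino group rather than chloro, so that measured step bears on it only loosely. Compound 4 is therefore expected to land not far from compound 2, with a step estimated at a 1.6-fold lower number from compound 2 to compound 4 (0.19 log units; within the scatter), and with a wide band of uncertainty around it. The estimate for compound 4 is 6000 nM, with a range from 1500 nM to 40000 nM.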

Compound 4, concentration lethal to 50% of the cells: 50100 nM
For compound 4 the middle estimate is 8.4-fold (0.92 log units) below the measured one; the measured number lies above the stated range.
By their numbers in this assay, from the lowest: compound 1; then compound 2; then compound 4. At a limit, above all of these: compound 3.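

In this assay, the position between two ring nitrogen atoms now carries three different occupants, and the amino compound gives the highest number of the three, with a 5.4-fold higher number from compound 2 to compound 4 (0.73 log units; beyond the scatter) on top of the earlier move from chloro to hydrogen. So the earlier step could have meant that any group at this position lowers the number relative to hydrogen, but amino does the opposite: chloro and amino fall on opposite sides of hydrogen, which makes the identity of the group count here, not merely whether one is present. Exchanging one group for the other directly spans the widest gap among these three compounds, a 16-fold higher number from compound 1 to compound 4 (1.21 log units; beyond the scatter) and a large step in this series, while nothing measured here accounts for that order.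

The compounds shown leave open where a methyl, a methoxy or a hydroxy group would fall at this position, and whether a substituted amine such as methylamino or dimethylamino would follow amino. They also leave open whether the amino step would hold if the remaining chloro group on the shared core were replaced by an amine or a thiol.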